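The source may report more compounds than this note shows. Statements on the series, on what has been measured and on what is new or still open speak of the compounds shown alone.

Going by the values given here, the three compounds measured so far share one core and differ only in the group on the amide-type nitrogen in the ring. Compound 1 `CCc1cccc(NC(=O)c2cccc(/C=C3\CC(=O)N(Cc4ccccc4)C3=O)c2)c1` carries a benzyl there. In an ADME assay on NCM460 cells (Homo sapiens) for cytotoxicity, read by MTT assay, with a stated time of 72 h (a higher number here means a weaker inhibitor, a lower number a stronger inhibitor), compound 1 gives only a limit, > 100000 nM. Compound 2 `CCc1cccc(NC(=O)c2cccc(/C=C3\CC(=O)N(c4ccccc4)C3=O)c2)c1` carries a phenyl. In this assay compound 2 likewise gives only a limit, > 100000 nM. Compound 3 `CCc1cccc(NC(=O)c2cccc(/C=C3\CC(=O)N(c4ccc(C)cc4)C3=O)c2)c1` carries a 4-methylphenyl. In this assay compound 3 also gives only a limit, > 100000 nM. Compound 2 thus stands where every measured value sits (the limit of > 100000 nM in this assay, at which 3 of the 3 values shown sit). The steps among them cannot be read: a step that the two limits leave unreadable from compound 1 to compound 2, a step that the two limits leave unreadable from compound 1 to compound 3 and a step that the two limits leave unreadable from compound 2 to compound 3. Compound 4 `O=C(Nc1ccc(OC(F)F)cc1)c1cccc(/C=C2\CC(=O)N(c3ccccc3)C2=O)c1` keeps the phenyl on the ring nitrogen and changes the other end of the molecule: 4-(difluoromethoxy)phenyl in place of 3-ethylphenyl on an amide-type nitrogen. Among the compounds with values here, no measured step touches that end, and none has a readable size, so no step beyond the scatter in this assay can be expected in either direction. The expected step from compound 2 to compound 4 is therefore a number no higher from compound 2 to compound 4 (the limit leaves the size open). Compound 4 is expected to give 100000 nM in this assay, within 30000 nM to 300000 nM, most probably again as a limit.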

Compound 4, half-maximal inhibitory concentration: > 100000 nM
Compound 4 was reported as a limit; the forecaster's own chance of this, stated with the estimate: 85%; the middle value sits exactly at the limit.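

In this assay, going by these compounds alone, compound 4, like compound 2, gives only a limit, so no step between compound 2 and compound 4 can be read: the limit of > 100000 nM in this assay, at which 4 of the 4 values shown sit. The compounds shown leave open whether a change at either end of the molecule alters the value at all.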